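From a Methyl Amide to a Dimethyl Amide

The source may hold more compounds than are shown below. What is called first, only, known or untested is meant among the compounds shown, and "the series" means these compounds.

Measured so far, each in an assay (Rattus norvegicus) for inhibition of Fatty-acid amide hydrolase 1 (Homo sapiens); on this read-out higher numbers stand for weaker inhibition and lower numbers for stronger inhibition:
Compound 1, `COc1ccc(-c2cnc(C(=O)CCCCCCc3ccccc3)o2)cc1`: 100 nM
Compound 2, `NS(=O)(=O)c1ccc(-c2cnc(C(=O)CCCCCCc3ccccc3)o2)s1`: 3 nM
Compound 3, `CNC(=O)c1cnc(C(=O)CCCCCCc2ccccc2)o1`: 7 nM

All three share the same core and differ only in the group on its aromatic carbon. In this assay compound 3 gives 7 nM, the second highest of the three numbers. Compound 2 lies nearest to it, with a step of a 2.3-fold higher number from compound 2 to compound 3 (0.37 log units; beyond the scatter), while compound 1 lies furthest, with a step of a 14-fold lower number from compound 1 to compound 3 (1.15 log units; beyond the scatter); the remaining step is a 33-fold lower number from compound 1 to compound 2 (1.52 log units; beyond the scatter).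

Compound 4, `CN(C)C(=O)c1cnc(C(=O)CCCCCCc2ccccc2)o1`, differs from compound 3 by methyl in place of hydrogen on an amide-type nitrogen. Among the compounds with values here, no measured step bears directly on this change: every step so far exchanges the whole substituent on the core, and none alters the amide nitrogen itself. What the data do show is that the methylcarbamoyl group of compound 3 sits among the lower numbers. Within the data shown here, with no step touching the amide hydrogen, the change from compound 3 to compound 4 is expected to be a 1.4-fold higher number from compound 3 to compound 4 (0.15 log units; within the scatter), a shift not beyond the scatter. Compound 4 is therefore estimated at 10 nM, with a range from 3 nM to 35 nM.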

Compound 4, inhibition constant: 2 nM
Beside the measured number, compound 4's estimate is 5.0-fold (0.70 log units) above it, outside the stated range (below it).
By their numbers in this assay, from the lowest: compounds 4 and 2 (each within the scatter of the next); then compound 3; then compound 1.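

In this assay, within the data shown here, the methyl on the amide-type nitrogen matters by itself: a 3.5-fold lower number from compound 3 to compound 4 (0.54 log units; beyond the scatter) is the first step here that changes only the amide nitrogen and keeps the rest of the substituent. With a 1.5-fold lower number from compound 2 to compound 4 (0.18 log units; within the scatter) the dimethylcarbamoyl and 5-sulfamoylthiophen-2-yl groups cannot be told apart on this read-out, whereas a 50-fold lower number from compound 1 to compound 4 (1.70 log units; beyond the scatter) is the widest step in the series, taking dimethylcarbamoyl in place of 4-methoxyphenyl. Nothing among the available data accounts for the effect of replacing the amide hydrogen with methyl.

The compounds shown leave open whether the primary carboxamide, with hydrogen on the nitrogen in place of both methyls, would continue this trend in the opposite direction. They also leave open whether ethyl groups on that nitrogen would give a number like that of compound 4 or a different one.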